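This account rests on a few compounds, and the source may have more. Where it says the series, first, only, none or still open, it means among the compounds named here.

Compound 3 `COc1cc2c(Oc3ccc(NC(=S)N/N=C/c4ccc(Cl)cc4)cc3F)ccnc2cc1OCCCN1CCCCC1` stands second highest of the three numbers gathered so far in a functional assay on MDA-MB-231 cells (Homo sapiens) for cytotoxicity, read by MTT assay, with a stated time of 72 h; on this read-out lower numbers stand for stronger inhibition and higher numbers for weaker inhibition: compound 3 gives 1300 nM. Its nearest neighbour is compound 2 `COc1cc2c(Oc3ccc(NC(=S)N/N=C/c4ccc(F)c(F)c4)cc3F)ccnc2cc1OCCCN1CCCCC1`, which in this assay gives 1400 nM, and its furthest is compound 1 `COc1cc2c(Oc3ccc(NC(=S)N/N=C/c4ccccc4)cc3F)ccnc2cc1OCCCN1CCCCC1`, which in this assay gives 1200 nM; both differences from compound 3 lie within the scatter. Compound 4 `COc1cc2c(Oc3ccc(NC(=S)N/N=C/c4ccc(F)cc4Cl)cc3F)ccnc2cc1OCCCN1CCCCC1` differs from compound 3 in one place: 2-chloro-4-fluorophenyl in place of 4-chlorophenyl on a carbon with a double bond to nitrogen. For the measured compounds named here, three measured steps bear on this kind of exchange on the group sitting on the carbon with a double bond to nitrogen: a 1.1-fold higher number from compound 1 to compound 3 (0.03 log units; within the scatter); a 1.2-fold higher number from compound 1 to compound 2 (0.07 log units; within the scatter); and a 1.1-fold lower number from compound 2 to compound 3 (0.03 log units; within the scatter). None of these exchanges moved the number beyond the scatter, so the present change gives no ground to expect a shift in either direction. In this assay compound 4 is therefore expected to stay within the scatter of the measured three, a step of no change at the digits printed from compound 3 to compound 4 (within the scatter). The estimate for compound 4 in this assay is 1300 nM, within a range from 700 nM to 2500 nM.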

Compound 4, half-maximal inhibitory concentration: 1400 nM
The estimate for compound 4 lay 1.1-fold (0.03 log units) below the measured number; the range from low to high includes it.
By their numbers in this assay, from the lowest: compounds 1, 3, 2 and 4 (each within the scatter of the next).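

In this assay, putting 2-chloro-4-fluorophenyl on the carbon with a double bond to nitrogen gives a 1.1-fold higher number from compound 3 to compound 4 (0.03 log units; within the scatter), no change at the digits printed from compound 2 to compound 4 (within the scatter) and a 1.2-fold higher number from compound 1 to compound 4 (0.07 log units; within the scatter). The earlier compounds shown here carried no more than one kind of halogen on this ring, whereas compound 4 carries chloro and fluoro together, and this exchange also stays within the scatter against each of the three. So all four groups shown at this place, from the plain phenyl to the one with two different halogens, cannot be told apart on this read-out.

The groups shown bear only chloro or fluoro, or nothing, so it stays open whether an amine, a carboxylic acid or a longer chain on this ring would move the number beyond the scatter. Nothing on hand explains why these exchanges leave the number in place.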